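The source may hold more compounds than are shown below. What is called first, only, known or untested is meant among the compounds shown, and "the series" means these compounds.

Going by the values given here, compound 2, `O=C1O[C@]2(CC[C@H](CNc3cnn(-c4ccccc4F)c3)CC2)CN1c1cccnc1`, is the compound with the lowest number among the two measured so far in a functional assay for antagonist activity at Neuropeptide Y receptor type 5 (Homo sapiens); a lower number here means a stronger inhibitor, a higher number a weaker inhibitor. In this assay compound 2 gives 0.1 nM. Among the compounds with values here, its only measured neighbour is compound 1, `Cc1ncccc1N1C[C@]2(CC[C@@H](CNc3cnn(-c4ccccc4F)c3)CC2)OC1=O`, which carries a methyl group on an aromatic carbon; in this assay compound 1 gives 0.631 nM. Within the data shown here, the single measured step, a 6.3-fold lower number from compound 1 to compound 2 (0.80 log units; beyond the scatter), tells that removing the methyl group made the number smaller.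

Compound 3, `O=C1O[C@]2(CC[C@H](CNc3cnn(-c4ccccc4F)c3)CC2)CN1c1ccnnc1`, has not yet been measured. It differs from compound 2 in a single place: pyridazin-4-yl in place of pyridin-3-yl on an amide-type nitrogen in a ring. The measured step between compound 1 and compound 2 concerns a methyl group on an aromatic carbon, not an exchange of one six-membered aromatic ring for another, so it bears only indirectly on the change to compound 3. Among the measured compounds shown here, no measured pair shows what a second ring nitrogen in this position does. The expectation is therefore a step of about a 2.0-fold higher number from compound 2 to compound 3 (0.30 log units; within the scatter), which is within the usual scatter. Compound 3 is estimated to give 0.2 nM in this assay, with a likely range from 0.05 nM to 0.8 nM.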

Compound 3, inhibition constant: 0.2 nM
The estimate for compound 3 equals the measured number at the digits printed; low and high end bracket the measured number.
By their numbers in this assay, from the lowest: compounds 2 and 3 (each within the scatter of the next); then compound 1.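

In this assay, pyridazin-4-yl in place of pyridin-3-yl on the amide-type nitrogen gives a 2.0-fold higher number from compound 2 to compound 3 (0.30 log units; within the scatter) and so shows that this position takes a second ring nitrogen in the six-membered aromatic ring with no difference that can be told from the scatter. Set against the methyl-bearing ring of compound 1, the new ring gives a 3.2-fold lower number from compound 1 to compound 3 (0.50 log units; beyond the scatter) and this step lies beyond the scatter, so compound 2 and compound 3 both stand on the same side of compound 1 with a ring that carries no methyl group. No supporting data are available to say why the second ring nitrogen is accommodated here.

The compounds shown leave open whether the placement of the second ring nitrogen matters, since a pyrimidin-5-yl ring or a plain phenyl ring on the same nitrogen would test the number and the site of ring nitrogens more fully. On these data alone, it also remains open whether a methyl group on the pyridazin-4-yl ring would carry the same penalty as the one seen on the pyridine ring of compound 1.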